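Extending the amide-bearing chain of compound 1

A few compounds are considered here, and "the series" means these few. Any claim that something is new, unique, unknown or untested is made for them only; others in the source may bear on it.

Within the data shown here, compound 1 `CCc1cc(C(C)=O)c(O)cc1OCCCC(C)(C)C(N)=O` is one of two compounds measured in an assay on isolated protein for binding affinity to leukotriene B4 receptor 1 (Homo sapiens), tested at 1 uM; on this read-out higher numbers stand for more inhibition at the one concentration tested (going by the name of the read-out) and lower numbers for less inhibition. In this assay compound 1 gives 51%. Compound 2 `C=CCc1cc(C(C)=O)c(O)cc1OCCCCCC(C)=O` gives 58% in this assay; the two numbers lie within the scatter of each other, so neither compound can be ranked against the other on this read-out. Compound 3 `CCc1cc(C(C)=O)c(O)cc1OCCCCCCC(=O)N(C)C` has not yet been measured. Compared with compound 1, it carries 3-(dimethylcarbamoyl)propyl in place of 1-carbamoyl-1-methylethyl on a saturated chain carbon, three bonds along the chain from an oxygen on an aromatic ring. Among the measured compounds shown here, no measured pair shows the effect of a change of this kind, so the expectation rests on the two numbers alone, which sit close together. Only a small step, if any, is expected, a number 3 percentage points higher from compound 1 to compound 3 (within the scatter), with no direction beyond the scatter. Compound 3 is therefore estimated to reach 54% in this assay, within a range from 30% to 78%.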

Compound 3, a percentage reported as inhibition, at one concentration (the size of the read-out at that concentration, not a potency): 61%
Estimate against measurement, compound 3: 7 percentage points below; measured number inside the range.
By their numbers in this assay, from the lowest: compounds 1, 2 and 3 (each within the scatter of the next).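

Among these compounds, the exchange of 1-carbamoyl-1-methylethyl for 3-(dimethylcarbamoyl)propyl gives the first measured step at this place, on a saturated chain carbon, three bonds along the chain from an oxygen on an aromatic ring: in this assay the change amounts to a step within the scatter (a number 10 percentage points higher from compound 1 to compound 3 (within the scatter)). The group that enters has 8 heavy atoms against 6 and 0 hydrogen-bond donors against 1, so on this read-out a change of this size at this place does not shift the number beyond the scatter. No measurement on these compounds bears on the reason for this result.

The step alters the chain length, the amide nitrogen and the branching at once, so the compounds shown cannot separate these parts. As far as these compounds go, it also remains open whether a carboxylic acid or an amine at the chain end, or a longer chain, would move the number beyond the scatter.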